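The source may hold more compounds than are shown below. What is called first, only, known or untested is meant among the compounds shown, and "the series" means these compounds.

Measured so far in an ADME assay on L6 cells (Rattus norvegicus) for cytotoxicity; a lower number here means a stronger inhibitor, a higher number a weaker inhibitor:

- compound 1 `N=C(N)c1cccc(-c2cc3cc(C(=N)N)ccc3o2)c1`: 21200 nM
- compound 2 `N=C(N)c1cccc(-c2cc3ccc(C(=N)N)cc3o2)c1`: 131000 nM
- compound 3 `COc1cc(C(=N)N)ccc1-c1cc2cc(C(=N)N)ccc2o1`: 157000 nM

Of these three, compound 1 has the lowest number, so it is the most toxic to the cells in this test. The gaps separating it from compound 2 and from compound 3 both lie beyond the usual scatter of repeated measurements.

The next compound to be tested is compound 4 `N=C(N)c1ccc(O)c(-c2cc3cc(C(=N)N)ccc3o2)c1`. It is compound 1 with hydroxy in place of hydrogen on an aromatic carbon.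

For the measured compounds named here, no pair of measured compounds differs in only one place, so no measured step shows directly what this change does. The evidence is indirect and thin. Compound 1 stands at 21200 nM, while compound 2 reaches 131000 nM and compound 3 reaches 157000 nM. With compound 1 the lowest of the three, a change to it seems more likely to raise the number than to lower it. A moderate rise in this assay is therefore expected, though one that may only just clear the scatter.

The expected change is a 2.1-fold higher number from compound 1 to compound 4 (0.33 log units; beyond the scatter).

For compound 4 the estimated value is 45000 nM, with an expected range from 15000 nM to 140000 nM.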

Compound 4, half-maximal inhibitory concentration: > 217000 nM
Compound 4 was reported as a limit; the forecaster's own chance of this, stated with the estimate: 8%; middle value at least 4.8-fold (0.68 log units) away from the limit.
By their numbers in this assay, from the lowest: compound 1; then compounds 2 and 3 (each within the scatter of the next). At a limit, above all of these: compound 4.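

In this assay, compound 4 is reported only as a limit, > 217000 nM. Placing hydroxy on this aromatic carbon, ortho to a large group and para to a group of 3 heavy atoms, gives an at least 10-fold higher number from compound 1 to compound 4 (1.01 log units; beyond the scatter), so this one small change at this position is enough to produce a large step, something the earlier compounds could not show because none of them formed a pair differing in only one place. The step therefore has a known lower end but no known upper end: the limit of > 217000 nM in this assay, at which 1 of the 4 values shown sits.

The compounds shown leave open whether this large rise is special to hydroxy or would also follow from another group on the same carbon, such as an amine, a carboxylic acid or a fluorine atom. They also leave open whether hydroxy would produce a step of similar size on another carbon of this ring, or on the same kind of carbon in compound 2, where the shared groups are arranged differently.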